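Shortening the Amino-Acid Amide on a Shared Core

A few compounds are considered here, and "the series" means these few. Any claim that something is new, unique, unknown or untested is made for them only; others in the source may bear on it.

Measured compounds:
compound 1, `C#CC(C)OC(=O)c1ccc(C(CC)(CC)c2ccc(OCCC(O)(CC)CC)c(C)c2)n1CC`, in an assay on cells for agonist activity at vitamin D3 receptor (Homo sapiens), with a stated time of 96 h (on this read-out lower numbers stand for an effect already at smaller amounts and higher numbers for an effect only at larger amounts of compound), gives 2650 nM
compound 2, `CCn1c(C(=O)Nc2ccc(OC(F)(F)F)cc2)ccc1C(CC)(CC)c1ccc(OCCC(O)(CC)CC)c(C)c1`, in this assay reaches only a limit, > 10000 nM
compound 3, `CCOC(=O)C(CC(=O)OC)NC(=O)c1ccc(C(CC)(CC)c2ccc(OCCC(O)(CC)CC)c(C)c2)n1CC`, in this assay gives 21 nM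

Among these numbers compound 3 stands lowest: a 130-fold lower number from compound 1 to compound 3 (2.10 log units; beyond the scatter), and, taking the limit of compound 2 as a bound, an at least 470-fold lower number from compound 2 to compound 3 (2.67 log units; beyond the scatter). The value of compound 2 is a limit of the assay and not a number (the limit of > 10000 nM in this assay, at which 1 of the 3 values shown sits).

Compound 4, `CCn1c(C(=O)NC(C)C(=O)O)ccc1C(CC)(CC)c1ccc(OCCC(O)(CC)CC)c(C)c1`, keeps the amide of compound 3 but carries a smaller group on it: a group of 5 heavy atoms (3 carbon, 2 oxygen; no ring) in place of a group of 11 heavy atoms (7 carbon, 4 oxygen; no ring), on an amide-type nitrogen. Among the measured compounds shown here, both measured steps into compound 3 touch this same position, and both were large, so the nature of the group on the amide nitrogen clearly matters here; yet neither step removes the second ester while leaving a free acid, so no measured step tells directly how compound 4 will fare. A modest loss is expected, with the estimate for compound 4 at 100 nM (range 15 nM to 700 nM), which means an expected step of a 4.8-fold higher number from compound 3 to compound 4 (0.68 log units; beyond the scatter).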

Compound 4, half-maximal effective concentration: 66 nM
For compound 4 the middle estimate is 1.5-fold (0.18 log units) above the measured one, and the stated range covers the measured number.
By their numbers in this assay, from the lowest: compound 3; then compound 4; then compound 1. At a limit, above all of these: compound 2.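

Among the compounds shown here, replacing the larger group on the amide-type nitrogen with 1-carboxyethyl costs only a modest step, a 3.1-fold higher number from compound 3 to compound 4 (0.50 log units; beyond the scatter), far smaller than the earlier steps into compound 3 at this place. A low number here therefore does not depend on the group of 11 heavy atoms in compound 3, and the (1-carboxyethyl)amino group still compares well with the (1-methylprop-2-yn-1-yl)oxy group, with a 40-fold lower number from compound 1 to compound 4 (1.60 log units; beyond the scatter). Against 4-(trifluoromethoxy)phenyl on the same nitrogen the step is an at least 150-fold lower number from compound 2 to compound 4 (2.18 log units; beyond the scatter), and it is only a bound, as the value of compound 2 is a limit: the limit of > 10000 nM in this assay, at which 1 of the 4 values shown sits.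

Compound 4 differs from compound 3 in both the size of the group and its free carboxylic acid, and the compounds shown cannot separate the two. From the compounds shown here alone, how a methyl ester of the 1-carboxyethyl group, or a longer chain ending in the carboxylic acid, would fare remains open.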